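The source may report more compounds than this note shows. Statements on the series, on what has been measured and on what is new or still open speak of the compounds shown alone.

In an ADME assay on HepG2 cells (Homo sapiens) for cytotoxicity, read by resazurin assay, with a stated time of 24 h (on this read-out lower numbers stand for stronger inhibition and higher numbers for weaker inhibition), compound 1 (`COc1cc2[nH]c(C)c(-c3ccc(Oc4cccc(OC(F)(F)F)c4)cc3)c(=O)c2cc1Cl`) stands at > 10000 nM as a limit, not a number. Compound 2 (`COc1cc2[nH]c(C)c(-c3ccc(Oc4ccc(F)c(OC(F)(F)F)c4)cc3)c(=O)c2cc1Cl`) gives > 10000 nM as a limit too. Compound 3 (`COc1cc2[nH]c(C)c(-c3ccc(Oc4ccc(OC(F)(F)F)c(F)c4)cc3)c(=O)c2cc1Cl`) gives > 10000 nM as a limit too. All three values sit at the same limit (the limit of > 10000 nM in this assay, at which 3 of the 3 values shown sit). The step to compound 4 (`COc1cc2[nH]c(C)c(-c3ccc(Oc4ccc(C(F)(F)F)cn4)cc3)c(=O)c2cc1Cl`) puts 5-(trifluoromethyl)pyridin-2-yl in place of 3-(trifluoromethoxy)phenyl on an oxygen on an aromatic ring. For the measured compounds named here, the one measured step bearing on this is a step that the two limits leave unreadable from compound 1 to compound 2 with fluoro in place of hydrogen on an aromatic carbon, and it gives no size to carry over. No change beyond the scatter is expected in this assay (a step that the limit leaves unreadable from compound 1 to compound 4). Compound 4 is estimated at 15000 nM with an expected range from 6000 nM to 40000 nM and will probably be reported only as a limit.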

Compound 4, half-maximal inhibitory concentration: > 10000 nM
Compound 4 ended at the assay's limit (the forecaster's own chance of this, stated with the estimate: 85%); the middle value lies beyond the limit too.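

No size can be read for the step between compound 1 and compound 4, as both values are limits and not numbers: the limit of > 10000 nM in this assay, at which 4 of the 4 values shown sit.

The compounds shown leave open whether any change on the shared core gives a measurable cytotoxicity value.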